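The source may hold more compounds than are shown below. What is called first, only, known or untested is meant among the compounds shown, and "the series" means these compounds.

Working notes on the series.

Compound 1 `COc1cc(-n2ncnc2-c2ccc(OC(C)C)cc2)cc(OC)c1OC` is the reference point. In a functional assay on MCF7 cells (Homo sapiens) for antiproliferative activity, read by MTT assay, with a stated time of 72 h (a lower number here means a stronger inhibitor, a higher number a weaker inhibitor), compound 1 gives 610 nM, the lowest of the two numbers recorded; the nearest number, that of compound 3 `COc1ccc(-n2ncnc2-c2cc(OC)c(OC)c(OC)c2)cc1` at 7400 nM, lies above it by a gap beyond the scatter. Compound 2 `COc1cc(-c2ncnn2-c2cccc(N)c2)cc(OC)c1OC` gives only a limit of the assay, > 10000 nM, not a number. Among the measured compounds shown here, the one single-point step measured so far is an at least 1.3-fold lower number from compound 2 to compound 3 (0.13 log units; that floor lies within the scatter), where a 4-methoxyphenyl replaces a 3-aminophenyl on an aromatic nitrogen; compound 2 sits at the limit of > 10000 nM in this assay, at which 1 of the 3 values shown sits, so that step is a floor and is itself within the scatter.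

The step now followed goes from compound 1 to compound 4 `COc1cc(-n2ncnc2-c2ccc(F)cc2)cc(OC)c1OC`: fluoro in place of isopropoxy on an aromatic carbon. For the measured compounds named here, no measured step touches this position or this pair of groups; the one step recorded concerns a group on the aromatic nitrogen, not on the aromatic carbon changed here, and compound 1 and compound 3 are not a single-point pair, so their values show only that compound 1 gives the lower number. The expectation therefore rests on the size of the change alone: a group of four heavy atoms leaves and a single fluorine enters, and a moderate rise in number is expected, a 2.5-fold higher number from compound 1 to compound 4 (0.39 log units; beyond the scatter). Compound 4 is estimated at 1500 nM, within 500 nM to 5000 nM.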

Compound 4, half-maximal inhibitory concentration: > 10000 nM
Compound 4 was reported as a limit; the forecaster's own chance of this, stated with the estimate: 10%; at least 6.6-fold (0.82 log units) between middle value and limit.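

Among the compounds shown here, the change gives an at least 16-fold higher number from compound 1 to compound 4 (1.21 log units; beyond the scatter), the first measured step at this aromatic carbon, para to a large group, and it shows that the group held there decides whether this assay returns a number at all. Compound 4 gives only a limit of the assay, > 10000 nM, so the size of the step is a floor and its true size remains unknown: the limit of > 10000 nM in this assay, at which 2 of the 4 values shown sit.

Within this pair, then, the shared core does not keep a measurable number once isopropoxy gives way to fluoro, a sharper dependence on this position than the earlier compounds could show, since none of their recorded steps touched it.

One pair cannot separate the loss of isopropoxy from the arrival of fluoro, and the compounds shown do not tell which feature of the isopropoxy group matters. An ethoxy group, a longer chain such as butoxy, or a carboxylic acid on this same carbon would show whether a number returns and how it follows the group's size and kind.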